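Bromophenyl in Place of Thiophenyl on the Shared Core

The source may hold more compounds than are shown below. What is called first, only, known or untested is meant among the compounds shown, and "the series" means these compounds.

Among the measured compounds shown here, compound 3 `c1cn2cc(-c3ccsc3)nc(-c3ccc4ncn(C5CCCCC5)c4c3)c2n1` gives 5.56% in a functional assay on Hs-578T cells (Homo sapiens) for inhibition, read by sulforhodamine B assay, with a stated time of 48 h, tested at 10 uM (on this read-out lower numbers stand for less inhibition and higher numbers for more inhibition at the one concentration tested (going by the name of the read-out)), the lowest of the three numbers so far; compound 1 `c1ccc(-c2cn3ccnc3c(-c3ccc4ncn(C5CCCCC5)c4c3)n2)cc1` gives 23.8% and compound 2 `Fc1ccc(-c2cn3ccnc3c(-c3ccc4ncn(C5CCCCC5)c4c3)n2)cc1` gives 17.6%. Compound 4 `Brc1ccc(-c2cn3ccnc3c(-c3ccc4ncn(C5CCCCC5)c4c3)n2)cc1` differs from compound 3 in one place: 4-bromophenyl in place of thiophen-3-yl on an aromatic carbon. The two measured steps that bear on this are a number 18.2 percentage points lower from compound 1 to compound 3 (beyond the scatter) and a number 12 percentage points lower from compound 2 to compound 3 (beyond the scatter), both leading to the thiophen-3-yl compound, while a number 6.2 percentage points lower from compound 1 to compound 2 (within the scatter) shows that a halogen on the phenyl changed little. Reversing the direction, a modest rise is expected, roughly the size of the step from compound 2 to compound 3, so the step of a number 12.4 percentage points higher from compound 3 to compound 4 (beyond the scatter) is expected to lie beyond the scatter. Compound 4 is therefore estimated at 18%, within 8% to 30%.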

Compound 4, a percentage reported as inhibition, at one concentration (the size of the read-out at that concentration, not a potency): 24.5%
Compound 4: the middle estimate sits 6.5 percentage points below what was measured, and the stated range covers the measured number.
By their numbers in this assay, from the lowest: compound 3; then compounds 2, 1 and 4 (each within the scatter of the next).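

In this assay, the 4-bromophenyl group also stands clear of the thiophen-3-yl group, with a number 18.9 percentage points higher from compound 3 to compound 4 (beyond the scatter), so compound 3 now lies beyond the scatter of all three phenyl-bearing compounds. The halogen makes no readable difference, with a number 0.7 percentage points higher from compound 1 to compound 4 (within the scatter) and a number 6.9 percentage points higher from compound 2 to compound 4 (within the scatter), which extends what fluoro suggested to bromo. Nothing available gives a reason for the gap between the thiophen-3-yl compound and the others. Open, from the compounds shown here alone, is how an amine or a carboxylic acid on the phenyl ring would read here, and whether a longer chain could replace the ring at this place.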